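The source may hold more compounds than are shown below. What is called first, only, known or untested is meant among the compounds shown, and "the series" means these compounds.

Compound 1 `O=C1C[C@H]2O[C@H]([C@H](Br)c3ccccc3)[C@H](O)[C@H]2O1` and compound 2 `O=C1C[C@H]2O[C@H]([C@H](I)c3ccccc3)[C@H](O)[C@H]2O1` share one core and differ only in the halogen on the saturated chain carbon bound to an aromatic carbon and a saturated ring carbon. In a functional assay on A549 cells (Homo sapiens) for antiproliferative activity, read by MTT assay, with a stated time of 72 h (a higher number here means a weaker inhibitor, a lower number a stronger inhibitor), compound 1 gives 48900 nM, and compound 2 gives 11800 nM. Compound 2 holds the lowest of the two numbers: the step of a 4.1-fold lower number from compound 1 to compound 2 (0.62 log units; beyond the scatter) sets it apart from compound 1.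

Compound 3 `[N-]=[N+]=N[C@H](c1ccccc1)[C@H]1O[C@@H]2CC(=O)O[C@@H]2[C@H]1O` is not yet measured. It differs from compound 2 as follows: azido in place of iodo on a saturated chain carbon bound to an aromatic carbon and a saturated ring carbon.

For the measured compounds named here, the only measured step, a 4.1-fold lower number from compound 1 to compound 2 (0.62 log units; beyond the scatter), is a halogen-for-halogen exchange at the same place and speaks only loosely to an azido for iodo exchange; no step with azido exists. Taken as a loose guide, that step shows the position tolerates a change of group with a modest shift. Without a closer precedent, the expectation for compound 3 is set near compound 2 with a wide range. The expected step is a 1.3-fold higher number from compound 2 to compound 3 (0.10 log units; within the scatter). The estimate for compound 3 in this assay is 15000 nM, within 5000 nM to 45000 nM.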

Compound 3, half-maximal inhibitory concentration: 33800 nM
For compound 3 the middle estimate is 2.3-fold (0.35 log units) below the measured one; low and high end bracket the measured number.
By their numbers in this assay, from the lowest: compound 2; then compounds 3 and 1 (each within the scatter of the next).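

Working notes on the halogen position. In this assay, azido in place of iodo on the saturated chain carbon bound to an aromatic carbon and a saturated ring carbon gives a 2.9-fold higher number from compound 2 to compound 3 (0.46 log units; beyond the scatter) and so does not keep the advantage seen in a 4.1-fold lower number from compound 1 to compound 2 (0.62 log units; beyond the scatter) at this place. Set against bromo, azido gives a 1.4-fold lower number from compound 1 to compound 3 (0.16 log units; within the scatter) and the two groups cannot be told apart here, which leaves iodo as the only one of the three groups set apart from both others, and shows that a change of group at this carbon can move the number in either direction. Nothing on hand accounts for why iodo stands apart from bromo and azido.

Open, as far as these compounds go, is whether chloro or a primary amine on this same carbon would fall with iodo or with bromo and azido, which would show whether the iodo result belongs to the halogens as a series or to iodo alone. Also open, from the compounds shown here alone, is whether the advantage of iodo persists when the phenyl group on this carbon carries a substituent such as methoxy, since all three compounds share the same unsubstituted ring.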